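The source may hold more compounds than are shown below. What is called first, only, known or untested is meant among the compounds shown, and "the series" means these compounds.

Measured compounds:
- Compound 1, `N#CC1=C(N)Oc2c(c3nc4ccccc4nc3c3ccccc23)C12C(=O)N(Cc1cnnn1-c1ccc(Br)cc1)c1ccccc12`: 44300 nM
- Compound 2, `CCOc1ccc(-n2nncc2CN2C(=O)C3(C(C#N)=C(N)Oc4c3c3nc5ccccc5nc3c3ccccc43)c3ccccc32)cc1`: 25200 nM
- Compound 3, `CCc1ccccc1-n1nncc1CN1C(=O)C2(C(C#N)=C(N)Oc3c(N)cc4nc5ccccc5nc4c32)c2ccccc21`: 24600 nM

In a functional assay on A549 cells (Homo sapiens) for antiproliferative activity, read by MTT assay, with a stated time of 48 h (on this read-out higher numbers stand for weaker inhibition and lower numbers for stronger inhibition), compound 3 gives 24600 nM, the lowest of the three numbers, yet its gaps to compound 2 and to compound 1 both stay within the usual scatter, so the three compounds cannot be told apart on this read-out.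

Compound 4, `N#CC1=C(N)Oc2c(N)cc3nc4ccccc4nc3c2C12C(=O)N(Cc1cnnn1-c1cccc(C(F)(F)F)c1)c1ccccc12`, differs from compound 3 in one place: 3-(trifluoromethyl)phenyl in place of 2-ethylphenyl on an aromatic nitrogen. Among the compounds with values here, only one measured step bears on this. It is a 1.8-fold lower number from compound 1 to compound 2 (0.25 log units; within the scatter), where the substituent on the same kind of aryl group was exchanged, and that step stayed within the scatter. Compound 2 and compound 3 carry different groups on that same aryl position and give almost identical numbers. On these data an exchange of the aryl group on the triazole nitrogen has not moved the read-out, so for compound 4 no step beyond the scatter is expected in this assay, with a 1.1-fold lower number from compound 3 to compound 4 (0.03 log units; within the scatter) as the expected step. Compound 4 is therefore estimated at 23000 nM, within a range from 9000 nM to 60000 nM.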

Compound 4, half-maximal inhibitory concentration: 5400 nM
For compound 4 the middle estimate is 4.3-fold (0.63 log units) above the measured one; the whole stated range lies above it.
By their numbers in this assay, from the lowest: compound 4; then compounds 3, 2 and 1 (each within the scatter of the next).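

In this assay, the aryl group on the aromatic nitrogen of the five-membered ring does affect the read-out: 3-(trifluoromethyl)phenyl in place of 2-ethylphenyl gives a 4.6-fold lower number from compound 3 to compound 4 (0.66 log units; beyond the scatter) and is a modest but real gain. Among the compounds shown, this is the only step at this position to pass beyond the scatter, whereas ethoxy in place of bromo gave a 1.8-fold lower number from compound 1 to compound 2 (0.25 log units; within the scatter) on the aryl group of a different core. No measurement at hand accounts for this step.

The step changes both the substituent and its place on the phenyl ring, so the two contributions cannot be separated. A 3-ethylphenyl or 2-(trifluoromethyl)phenyl group on the same core would show which one matters, and a plain phenyl group would give a baseline for both.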